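Compound 4: an oxadiazole isomer in the cytotoxicity assay

The source may hold more compounds than are shown below. What is called first, only, known or untested is meant among the compounds shown, and "the series" means these compounds.

Measured in an ADME assay on Vero cells (Chlorocebus sabaeus) for cytotoxicity, read by MTT assay; a higher number here means a weaker inhibitor, a lower number a stronger inhibitor:
Compound 1 `Cc1nc(C#N)c(N)c2c1C(=O)N(Cc1ccccc1)C2=O`: "not determined" (no result reported)
Compound 2 `Cc1nc(C(=O)N(C)C)c(N)c2c1C(=O)N(Cc1ccccc1)C2=O`: > 100000 nM, a limit of the assay
Compound 3 `Cc1nnc(-c2nc(C)c3c(c2N)C(=O)N(Cc2ccccc2)C3=O)o1`: > 100000 nM, a limit of the assay

Compound 3 stands only at a limit, > 100000 nM, and so offers no exact number as a starting point. Compound 4 `Cc1noc(-c2nc(C)c3c(c2N)C(=O)N(Cc2ccccc2)C3=O)n1` keeps the shared core and has the same atoms joined differently: 3-methyl-1,2,4-oxadiazol-5-yl in place of 5-methyl-1,3,4-oxadiazol-2-yl, on an aromatic carbon ortho to an amino group (3-methyl-1,2,4-oxadiazol-5-yl in place of 5-methyl-1,3,4-oxadiazol-2-yl on an aromatic carbon).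

Among the measured compounds shown here, one measured step bears on this change, a step that the two limits leave unreadable from compound 2 to compound 3. It replaces dimethylcarbamoyl with the oxadiazole that compound 4 now rearranges, and both of its ends are limits, so it has no readable size. The firmest observation is the limit of > 100000 nM in this assay, at which 2 of the 3 values shown sit. Compound 1 adds nothing, having no result. On this thin basis, no step beyond the scatter is expected in this assay, and no direction can be argued with confidence. The expected change, a step that the limit leaves unreadable from compound 3 to compound 4, is therefore an estimate that carries little weight, and a report of only a limit is the likeliest outcome. For compound 4 the estimate is 120000 nM, with an expected range of 60000 nM to 250000 nM.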

Compound 4, half-maximal inhibitory concentration: > 100000 nM
Compound 4: only a limit was reported; the forecaster's own chance of this, stated with the estimate: 85%; the middle value is on the limit's open side.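

In this assay compound 4 gives > 100000 nM, which is a limit of the assay. Among the compounds shown here, no step among compound 2, compound 3 and compound 4 can be read, as each has only a limit. The compounds shown leave open whether dimethylcarbamoyl, 5-methyl-1,3,4-oxadiazol-2-yl and 3-methyl-1,2,4-oxadiazol-5-yl differ at all in this assay.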